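The compounds below may be only part of what the source reports. "The series", "measured", "known", "first", "only" and "open" are said of these compounds alone.

For the measured compounds named here, compound 2, whose structure is `N#CC1=C(N)Oc2c(N)cc3nc4ccccc4nc3c2C12C(=O)N(Cc1cnnn1-c1cccc(C(F)(F)F)c1)c1ccccc12`, is the only compound here with a measured number in a functional assay on A549 cells (Homo sapiens) for antiproliferative activity, read by MTT assay, with a stated time of 48 h; a higher number here means a weaker inhibitor, a lower number a stronger inhibitor: in this assay compound 2 gives 5400 nM. Its companion, compound 1, with the structure `N#CC1=C(N)Oc2c(c3nc4ccccc4nc3c3ccccc23)C12C(=O)N(Cc1cnnn1-c1ccc(Cl)c(Cl)c1)c1ccccc12`, has no number of its own; in this assay compound 1 reaches only a limit, > 50000 nM. Compound 1 thus stands at the limit of > 50000 nM in this assay, at which 1 of the 2 values shown sits. Compound 1 and compound 2 differ in more than one place, so their two values say nothing about any single change.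

Compound 3, with the structure `N#CC1=C(N)Oc2c(N)cc3nc4ccccc4nc3c2C12C(=O)N(Cc1cnnn1-c1ccc(F)c(Cl)c1)c1ccccc12`, is not yet measured. It differs from compound 2 only in one place: 3-chloro-4-fluorophenyl in place of 3-(trifluoromethyl)phenyl on an aromatic nitrogen. Going by the values given here, with no measured step of this kind to lean on, the expected change from compound 2 to compound 3 in this assay is small, most likely within the usual scatter, leaning if anything toward a somewhat weaker inhibitor. Compound 3 is therefore expected to give about 7000 nM, between 2500 nM and 25000 nM, a step of a 1.3-fold higher number from compound 2 to compound 3 (0.11 log units; within the scatter).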

Compound 3, half-maximal inhibitory concentration: 43400 nM
The estimate for compound 3 lay 6.2-fold (0.79 log units) below the measured number; the whole stated range lies below it.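

In this assay, the group on the aromatic nitrogen proves to matter: 3-chloro-4-fluorophenyl in place of 3-(trifluoromethyl)phenyl gives an 8.0-fold higher number from compound 2 to compound 3 (0.91 log units; beyond the scatter). Both groups are a single six-membered aromatic carbon ring with no hydrogen-bond donors or acceptors and no net charge, so these counts do not separate them and the step rests on the ring's substituents alone. Compound 1 differs from both others in more than one place, so no step to it can be read, and it stands only at a limit: the limit of > 50000 nM in this assay, at which 1 of the 3 values shown sits.

The swap replaces the trifluoromethyl group and adds chlorine and fluorine at once, so this single step cannot assign the change to any one of them. On these data alone, how a plain phenyl, a 3-chlorophenyl, or a ring bearing an amine or a carboxylic acid would read at this position stays open.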